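Solubility of compound 4 after a pyridinyl-for-fluorophenyl swap

This account rests on a few compounds, and the source may have more. Where it says the series, first, only, none or still open, it means among the compounds named here.

The shared core of compound 1 `Cc1nc(C(N)=O)c(N)c2c1C(=O)N(Cc1ccccc1)C2=O` carries a primary amide; in a physicochemical assay for solubility, using the shake flask method, in simulated intestinal fluid, measured as kinetic solubility, with a stated time of 2 h, at 25 degrees C, at pH 6.5 (a higher number here means a more soluble compound, a lower number a less soluble compound), compound 1 gives only the assay limit of < 5000 nM. Compound 2 `CNC(=O)c1nc(C)c2c(c1N)C(=O)N(Cc1ccccc1)C2=O` carries a methyl on that amide nitrogen, and in this assay compound 2 gives 41000 nM. Going by the values given here, the step of an at least 8.2-fold higher number from compound 1 to compound 2 (0.91 log units; beyond the scatter) is the only measured step here, and it concerns a different place than the change considered below. Compound 3 `Cc1noc(-c2nc(C)c3c(c2N)C(=O)N(Cc2cccc(F)c2)C3=O)n1` gives in this assay only the assay limit of < 5000 nM, so its true solubility is known only as a limit, a position it shares with one other value, as noted in the limit of < 5000 nM in this assay, at which 2 of the 3 values shown sit. Compound 4 `Cc1noc(-c2nc(C)c3c(c2N)C(=O)N(Cc2ccncc2)C3=O)n1` differs from compound 3 by pyridin-4-yl in place of 3-fluorophenyl on a saturated chain carbon bound to an amide-type nitrogen in a ring. Among the compounds with values here, no measured step covers this change, so the expectation rests on the structural change alone. Compound 4 is expected to reach 20000 nM, within 4000 nM to 100000 nM, meaning an estimated step of an at least 4.0-fold higher number from compound 3 to compound 4 (0.60 log units; beyond the scatter).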

Compound 4, solubility: 26400 nM
Beside the measured number, compound 4's estimate is 1.3-fold (0.12 log units) below it, and the stated range covers the measured number.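

In this assay, going by these compounds alone, pyridin-4-yl in place of 3-fluorophenyl gives an at least 5.2-fold higher number from compound 3 to compound 4 (0.72 log units; beyond the scatter), the only measured step on the saturated chain carbon bound to an amide-type nitrogen in a ring, whereas the earlier step concerned the amide nitrogen. Compound 3 gives < 5000 nM, which is a limit of the assay and not a number, so the step sets only a lower bound on the size of this change. A change at this place alone thus lifts the compound clear of that limit, leaving the rest of compound 3 as it was: the limit of < 5000 nM in this assay, at which 2 of the 4 values shown sit.

The step combines the loss of fluorine with the entry of a ring nitrogen, and the compounds shown do not separate the two. On these data alone, how pyridin-3-yl or an aminoethyl chain would read at this place also remains open.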